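The compounds below may be only part of what the source reports. "The series", "measured", "known", "first", "only" and "open" are said of these compounds alone.

Measured so far, all in an assay on mitochondria (strain BALB/c) for inhibition of glycerol-3-phosphate acyltransferase 1, mitochondrial (Mus musculus), read by scintillation counting, with a stated time of 10 min; on this read-out higher numbers stand for weaker inhibition and lower numbers for stronger inhibition:
compound 1 `CCCCCCCCS(=O)(=O)Nc1ccc(-c2ccc(CCCC)cc2)cc1C(=O)O` — 9000 nM
compound 2 `CCCCCCCCS(=O)(=O)Nc1ccc(-c2ccc(OC)cc2)cc1C(=O)O` — 19500 nM
compound 3 `CCCCCCCCS(=O)(=O)Nc1ccc(-c2cccc(F)c2)cc1C(=O)O` — 37600 nM

Compound 3 gives the highest number of the three. Against compound 2 the gap is a 1.9-fold higher number from compound 2 to compound 3 (0.29 log units; within the scatter), so the two cannot be ordered; against compound 1 it is a 4.2-fold higher number from compound 1 to compound 3 (0.62 log units; beyond the scatter), a real difference. Compound 1 to compound 2 shows a 2.2-fold higher number from compound 1 to compound 2 (0.34 log units; beyond the scatter).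

Compound 4 `CCCCCCCCS(=O)(=O)Nc1ccc(C(=O)c2ccc(OC)cc2)cc1C(=O)O` has not been measured. The change from compound 3 is (4-methoxyphenyl)carbonyl in place of 3-fluorophenyl on an aromatic carbon. Two things happen at once: the aryl group that enters carries methoxy, as in compound 2, and a carbonyl is inserted between the shared core and that aryl ring. The methoxyphenyl part is covered by compound 2, whose value in this assay is 19500 nM and whose gap to compound 3 is within the scatter. Among the compounds with values here, the inserted carbonyl has no counterpart among the measured compounds, so no step informs on it, and the expectation must lean on compound 2 alone with a widened range.

Compound 4 is therefore expected to land near compound 2 and compound 3, a step of a 1.7-fold lower number from compound 3 to compound 4 (0.23 log units; within the scatter), with no change beyond the scatter foreseen. The estimate for compound 4 is 22000 nM, within 7000 nM to 70000 nM.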

Compound 4, half-maximal inhibitory concentration: 44300 nM
For compound 4 the middle estimate is 2.0-fold (0.30 log units) below the measured one, and the stated range covers the measured number.
By their numbers in this assay, from the lowest: compound 1; then compounds 2, 3 and 4 (each within the scatter of the next, the first and the last beyond it).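

In this assay, within the data shown here, the carbonyl gives the first reading on a linker at the aromatic carbon meta to the carboxy group: with the 4-methoxyphenyl ring kept, its insertion gives a 2.3-fold higher number from compound 2 to compound 4 (0.36 log units; beyond the scatter), so direct attachment of this ring and attachment through a carbonyl can be told apart, though only modestly. Set against the 3-fluorophenyl group, the (4-methoxyphenyl)carbonyl group gives a 1.2-fold higher number from compound 3 to compound 4 (0.07 log units; within the scatter), so these two groups cannot be ordered, while set against the 4-butylphenyl group it gives a 4.9-fold higher number from compound 1 to compound 4 (0.69 log units; beyond the scatter), the widest gap in the series so far and still a modest one. Nothing at hand bears on why the carbonyl shifts the number in this way.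

Open, as far as these compounds go, is whether a methylene or an ether oxygen in place of the carbonyl would give a similar step, and whether the same step would appear with a (4-butylphenyl)carbonyl group. Also open, from the compounds shown here alone, is whether a longer chain, such as hexyl, on the aryl ring would lower the number further than the butyl group of the best-reading compound does.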